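Chloro for methyl on the benzamide of a menthyl scaffold

The source may report more compounds than this note shows. Statements on the series, on what has been measured and on what is new or still open speak of the compounds shown alone.

Measured compounds:
compound 1 `Cc1ccc(C(=O)N[C@@H]2C[C@H](C)CC[C@H]2C(C)C)cc1` gives 2200 nM
compound 2 `CC(C)[C@@H]1CC[C@@H](C)C[C@H]1NC(=O)CCCCCCc1ccccc1` gives 400 nM

Two amides sharing one core have been tested in a functional assay on HEK293 cells for antagonist activity at transient receptor potential cation channel subfamily M member 8 (Rattus norvegicus), read by calcium flux; on this read-out lower numbers stand for stronger inhibition and higher numbers for weaker inhibition. Compound 1 has the higher of the two numbers; compound 2 sits at the lower one, and the gap between them lies beyond the usual scatter of this assay. Among the compounds with values here, no other pair has been compared directly.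

Compound 3 `CC(C)[C@@H]1CC[C@@H](C)C[C@H]1NC(=O)c1ccc(Cl)cc1` keeps the core of compound 1 and changes one group on its aromatic ring: chloro in place of methyl on an aromatic carbon. No measured step of this kind exists among these compounds, so the expectation rests on compound 1 alone with its 2200 nM. The swap of one single heavy atom for another is expected to move the number little, if at all, with perhaps a slight shift toward stronger inhibition that may stay within the scatter; the expected step is a 1.5-fold lower number from compound 1 to compound 3 (0.17 log units; within the scatter). Compound 3 is estimated at 1500 nM, within a range from 500 nM to 5000 nM.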

Compound 3, half-maximal inhibitory concentration: 700 nM
For compound 3 the middle estimate is 2.1-fold (0.33 log units) above the measured one; low and high end bracket the measured number.
By their numbers in this assay, from the lowest: compounds 2 and 3 (each within the scatter of the next); then compound 1.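

In this assay, within the data shown here, chloro in place of methyl on this aromatic carbon, para to a large group, gives a 3.1-fold lower number from compound 1 to compound 3 (0.50 log units; beyond the scatter) and so provides the first direct step between two compounds that differ in one place. The step is modest but lies beyond the scatter, which shows that the number at this position responds to the exchange of one heavy atom for another, although neither group carries a hydrogen-bond donor, a hydrogen-bond acceptor or a net charge. No measurement offered here explains why the chloro compound gives the lower number.

Going by these compounds, how a trifluoromethyl group, a nitrile, an amine or a carboxylic acid would read at the same position remains open. On these data alone, it is also open whether the same exchange would give a similar step on the phenyl ring of compound 2, which sits at the end of a longer chain.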